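From 4-methylphenyl to 4-fluorophenyl in a small series

The source may hold more compounds than are shown below. What is called first, only, known or untested is meant among the compounds shown, and "the series" means these compounds.

Three compounds with a shared core have numbers in a functional assay on A-375 cells (Homo sapiens) for cytotoxicity, read by CCK-8 assay, with a stated time of 24 h; on this read-out lower numbers stand for stronger inhibition and higher numbers for weaker inhibition. There, compound 1 `COc1ccccc1Oc1c(N)nc(-c2ccc(F)cc2)nc1Cl` gives 28200 nM, compound 2 `COc1ccccc1Oc1c(N)nc(-c2cccc(C)c2)nc1OCCO` gives 1380 nM, and compound 3 `COc1ccccc1Oc1c(N)nc(-c2ccc(C)cc2)nc1OCCO` gives 2380 nM. Compound 3 lies close to its nearest value, a 1.7-fold higher number from compound 2 to compound 3 (0.24 log units; within the scatter), while compound 1 stands far higher, beyond the scatter.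

Compound 4 `COc1ccccc1Oc1c(N)nc(-c2ccc(F)cc2)nc1OCCO` has not yet been measured. It differs from compound 3 in one place, on an aromatic carbon of a six-membered aromatic ring of carbon only, para to a large group: fluoro in place of methyl on an aromatic carbon. In words, this is fluoro in place of methyl on an aromatic carbon.

For the measured compounds named here, no measured step makes this exchange. Going by the values given here, the only step touching the same group is 4-methylphenyl in place of 3-methylphenyl, which came to a 1.7-fold higher number from compound 2 to compound 3 (0.24 log units; within the scatter). Compound 1 also carries the 4-fluorophenyl group, but it differs from compound 4 elsewhere, so its value cannot isolate the exchange.

In this assay, no step beyond the scatter is therefore expected, and the estimated change is a 1.1-fold higher number from compound 3 to compound 4 (0.02 log units; within the scatter). For compound 4 the expected value is 2500 nM, with an estimated range from 1000 nM to 7000 nM.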

Compound 4, half-maximal inhibitory concentration: 15900 nM
Compound 4: middle estimate off by 6.4-fold (0.80 log units), on the low side; measured number above the stated range.
By their numbers in this assay, from the lowest: compounds 2 and 3 (each within the scatter of the next); then compounds 4 and 1 (each within the scatter of the next).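

In this assay the choice of group at this position proves to matter: with the 2-hydroxyethoxy group kept, fluoro in place of methyl on an aromatic carbon para to a large group gives a 6.7-fold higher number from compound 3 to compound 4 (0.82 log units; beyond the scatter) and so moves the number beyond the scatter, which the shift of the methyl group alone, a 1.7-fold higher number from compound 2 to compound 3 (0.24 log units; within the scatter), did not do. The 3-methylphenyl compound shows the same separation from the 4-fluorophenyl compound with a 12-fold higher number from compound 2 to compound 4 (1.06 log units; beyond the scatter), so both methylphenyl compounds lie apart from compound 4 while staying within the scatter of each other. With the 4-fluorophenyl group in place, 2-hydroxyethoxy in place of chloro gives a 1.8-fold lower number from compound 1 to compound 4 (0.25 log units; within the scatter), so that exchange cannot be told from the scatter in this pair.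

The compounds shown leave open whether an amine or a nitrile at this place on the phenyl ring would stand with the methyl compounds or with the fluoro compound, and whether chloro in place of 2-hydroxyethoxy would also leave the number unresolved on a methylphenyl compound. Nothing available here explains the size of the step from methyl to fluoro.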